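Notes on the step from compound 3 to compound 4

The source may report more compounds than this note shows. Statements on the series, on what has been measured and on what is new or still open speak of the compounds shown alone.

Values in an ADME assay on microsomes from liver (Homo sapiens) for metabolic stability; on this read-out higher numbers stand for a longer-lived compound and lower numbers for a shorter-lived compound:
Compound 1 `COc1cc(OCc2cccc(-c3ccc(C(F)(F)F)cn3)c2)c2cc(-c3cn4nc(OC)sc4n3)oc2c1`: 0.733 h
Compound 2 `COc1cc(OCc2cccc(-c3ccc(OC)nc3)c2)c2cc(-c3cn4nc(OC)sc4n3)oc2c1`: 0.733 h
Compound 3 `COc1cc(OCc2csc(-c3ccc(C(=O)O)cc3)n2)c2cc(-c3cn4nc(OC)sc4n3)oc2c1`: > 2 h, which is a limit of the assay, not a number.

Among the measured compounds shown here, the only measured step, no change at the digits printed from compound 1 to compound 2 (within the scatter), concerns a change on a different part of the molecule and does not involve the carboxy group. Compound 3 sits at the limit (the limit of > 2 h in this assay, at which 1 of the 3 values shown sits), so only a range is known for it in this assay. Compound 4 `COc1cc(OCc2csc(-c3ccccc3)n2)c2cc(-c3cn4nc(OC)sc4n3)oc2c1` differs from compound 3 by hydrogen in place of carboxy on an aromatic carbon. For the measured compounds named here, no measured step bears on this change, so its size cannot be read from the series; a moderate downward step is expected, an at least 1.4-fold lower number from compound 3 to compound 4 (0.15 log units; that floor lies within the scatter), with a fair chance that the limit is reached again. Compound 4 is estimated at 1.4 h, in the range 0.6 h to 3.5 h.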

Compound 4, half-life: 1.33 h
Compound 4: the middle estimate sits 1.1-fold (0.02 log units) above what was measured; the measured number falls inside the stated range.
By their numbers in this assay, from the lowest: compounds 1, 2 and 4 (each within the scatter of the next). At a limit, above all of these: compound 3.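

In this assay, going from 4-carboxyphenyl to phenyl gives an at least 1.5-fold lower number from compound 3 to compound 4 (0.17 log units; that floor lies within the scatter). Compound 4 gives 1.33 h, so the phenyl end of this change has a measured number. Compound 3 stands at a limit of the assay, not a number, so the carboxy end has only a limit and this step has a floor and no upper size: the limit of > 2 h in this assay, at which 1 of the 4 values shown sits.

From the compounds shown here alone, the true size of the step stays open. So does the read-out of a methyl ester or an amine on this aromatic carbon, para to a large group.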